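Working notes: dimethylamino in place of methylsulfanyl

The compounds below may be only part of what the source reports. "The series", "measured", "known", "first", "only" and "open" are said of these compounds alone.

Three measured compounds share one core and differ at a single aromatic carbon. Compound 1 `CNc1nc(NC2(C#N)CCCCC2)nc(-n2cnc(C)n2)n1` carries 3-methyl-1H-1,2,4-triazol-1-yl there; in an in vitro assay on Sf21 cells for inhibition of high affinity 3',5'-cyclic-AMP phosphodiesterase 7A (Homo sapiens) (on this read-out lower numbers stand for stronger inhibition and higher numbers for weaker inhibition), compound 1 gives only a limit, > 5000 nM, namely (the limit of > 5000 nM in this assay, at which 1 of the 3 values shown sits). Compound 2 `CNc1nc(NC2(C#N)CCCCC2)nc(OC)n1` carries methoxy, and in this assay compound 2 gives 521 nM. Compound 3 `CNc1nc(NC2(C#N)CCCCC2)nc(SC)n1` carries methylsulfanyl, and in this assay compound 3 gives 46 nM, the lowest of the two numbers shown, with compound 2 nearest; that gap is the step of an 11-fold lower number from compound 2 to compound 3 (1.05 log units; beyond the scatter). The remaining steps run an at least 9.5-fold lower number from compound 1 to compound 2 (0.98 log units; beyond the scatter) and an at least 100-fold lower number from compound 1 to compound 3 (2.03 log units; beyond the scatter).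

Compound 4 `CNc1nc(NC2(C#N)CCCCC2)nc(N(C)C)n1` is not yet measured. Its change from compound 3 is dimethylamino in place of methylsulfanyl on an aromatic carbon. For the measured compounds named here, no measured step replaces a methylsulfanyl with an amine, so the nearest guide is the exchange of methylsulfanyl for methoxy, taken from an 11-fold lower number from compound 2 to compound 3 (1.05 log units; beyond the scatter) read in reverse, a large step; methoxy and methylsulfanyl alone span a wide range in this assay. The step of a 5.4-fold higher number from compound 3 to compound 4 (0.74 log units; beyond the scatter) is therefore expected to run upward, toward weaker inhibition, beyond the scatter yet short of the distance to compound 1. Compound 4 is estimated at 250 nM in this assay, within 50 nM to 1500 nM.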

Compound 4, half-maximal inhibitory concentration: > 5000 nM
Compound 4: only a limit was reported (the forecaster's own chance of this, stated with the estimate: 10%); middle value at least 20-fold (1.30 log units) away from the limit.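

Compound 4 reaches only a limit in this assay, the same limit as compound 1: the limit of > 5000 nM in this assay, at which 2 of the 4 values shown sit.

For the compounds shown here, at this position, opposite the ring nitrogen, dimethylamino in place of methylsulfanyl costs far more than any readable step among the earlier compounds, with an at least 100-fold higher number from compound 3 to compound 4 (2.03 log units; beyond the scatter), and methoxy also stands well clear of dimethylamino, with an at least 9.5-fold higher number from compound 2 to compound 4 (0.98 log units; beyond the scatter). The earlier compounds shown here tied a limit only to 3-methyl-1H-1,2,4-triazol-1-yl, whereas compound 4 shows that dimethylamino, with no ring, gives the same limit, so a ring at this carbon is not needed for inhibition to fall out of the measurable range.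

As far as these compounds go, the step between compound 1 and compound 4 cannot be read, since both values are limits, so the order of these two stays unknown. Also open, from the compounds shown here alone, is whether the loss belongs to an amine nitrogen at this carbon as such or to its two methyl groups, which a methylamino or unsubstituted amino group would separate, and whether a longer chain on the sulfur, such as ethylsulfanyl, would hold or improve on compound 3.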